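The source may report more compounds than this note shows. Statements on the series, on what has been measured and on what is new or still open speak of the compounds shown alone.

The measured compounds:

Compound 1 `Cc1ccc(CCC(=O)N[C@@H](C(=O)N2CCC(c3ccc(Cl)cc3)CC2)C(C)C)cc1` gives 105 nM.
Compound 2 `CC(C)C(NS(=O)(=O)Cc1ccccc1)C(=O)N1CCC(c2ccc(Cl)cc2)CC1` gives 303 nM.
Compound 3 `O=C(N[C@@H](C(=O)N1CCC(c2ccc(Cl)cc2)CC1)C1CCCCC1)c1ccccc1` gives 121 nM.

All three numbers come from an assay on THP-1 cells for displacement of a labelled ligand from C-C chemokine receptor type 1 (Homo sapiens); a lower number here means a stronger inhibitor, a higher number a weaker inhibitor. Compound 3 stands second highest of the three. Its nearest neighbour is compound 1, whose number is lower by an amount within the scatter, so the two cannot be told apart; compound 2 lies beyond the scatter on the higher side. The three compounds share a core but differ from one another in more than one place, so none of these gaps can be tied to a single change.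

Compound 4 `CC[C@@H](NC(=O)c1ccccc1)C(=O)N1CCC(c2ccc(Cl)cc2)CC1` has not yet been measured. It differs from compound 3 in one place: ethyl in place of cyclohexyl on a saturated chain carbon bound to an amide-type nitrogen and a carbonyl carbon. Among the compounds with values here, no measured pair shows this change on its own, so there is nothing to copy from. A ring of six carbons gives way to a two-carbon chain at this position, and the expectation is a modest rise in the number, roughly at the edge of the scatter, with the step of a 2.1-fold higher number from compound 3 to compound 4 (0.32 log units; beyond the scatter) expected in this assay. Compound 4 is therefore estimated at 250 nM, with a range from 80 nM to 800 nM.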

Compound 4, half-maximal inhibitory concentration: 121 nM
Compound 4: the middle estimate sits 2.1-fold (0.32 log units) above what was measured; the measured number falls inside the stated range.
By their numbers in this assay, from the lowest: compounds 1, 3 and 4 (each within the scatter of the next); then compound 2.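

In this assay, ethyl in place of cyclohexyl on a saturated chain carbon bound to an amide-type nitrogen and a carbonyl carbon gives no change at the digits printed from compound 3 to compound 4 (within the scatter). With the rest of compound 3 held fixed, the six-membered carbon ring is therefore not needed at this position to keep the number, and a two-carbon chain serves equally well in this assay. Nothing available here explains why the two groups match.

Still open, as far as these compounds go, is how wide the range of groups accepted at this position is: whether a methyl, a longer chain, or a chain ending in an amine or a carboxylic acid would also keep the number. It is also unknown whether ethyl and cyclohexyl would still match if the benzamide part of compound 3 were exchanged for another group.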